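A few compounds are considered here, and "the series" means these few. Any claim that something is new, unique, unknown or untested is made for them only; others in the source may bear on it.

Measured compounds:
Compound 1, `CCCCCCCCCCn1cc(Cn2nc(N)c3c(C(F)(F)F)cc(-c4ccccc4)nc32)nn1`, gives 27.1 ug/mL in a functional assay on U-937 cells (Homo sapiens) for cytotoxicity, read by MTT assay, with a stated time of 24 h; on this read-out higher numbers stand for weaker inhibition and lower numbers for stronger inhibition.
Compound 2, `Nc1nn(Cc2cn(-c3ccc([N+](=O)[O-])cc3)nn2)c2nc(-c3ccccc3)cc(C(F)(F)F)c12`, gives 98.8 ug/mL in this assay.
Compound 3, `Cc1c(Br)cccc1-n1cc(Cn2nc(N)c3c(C(F)(F)F)cc(-c4ccccc4)nc32)nn1`, gives 97.2 ug/mL in this assay.

Compound 3 stands second highest of the three numbers in this assay: its value sits within the scatter of compound 2, as the step of a 1.0-fold lower number from compound 2 to compound 3 (0.01 log units; within the scatter) shows, while compound 1 lies well apart, as the step of a 3.6-fold higher number from compound 1 to compound 3 (0.55 log units; beyond the scatter) shows. Compound 4, `Cc1ccc(NC(=O)Cn2cc(Cn3nc(N)c4c(C(F)(F)F)cc(-c5ccccc5)nc43)nn2)cc1`, is not yet measured. It differs from compound 3 in one place: ((4-methylphenyl)carbamoyl)methyl in place of 3-bromo-2-methylphenyl on an aromatic nitrogen.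

Among the compounds with values here, no measured step makes this same change. The two steps that bear on it are a 3.6-fold higher number from compound 1 to compound 3 (0.55 log units; beyond the scatter) and a 3.6-fold higher number from compound 1 to compound 2 (0.56 log units; beyond the scatter), both modest, in which an aromatic group replaced the decyl chain; the exchange of one aromatic group for another, a 1.0-fold lower number from compound 2 to compound 3 (0.01 log units; within the scatter), lay within the scatter. Since the entering group again carries an aromatic ring, compound 4 is expected to stay near compound 3, with a step of a 1.3-fold lower number from compound 3 to compound 4 (0.11 log units; within the scatter) that is estimated to fall within the scatter. Compound 4 is therefore estimated at 75 ug/mL, in the range 30 ug/mL to 150 ug/mL.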

Compound 4, half-maximal inhibitory concentration: 65.3 ug/mL
Compound 4: middle estimate off by 1.1-fold (0.06 log units), on the high side; the range from low to high includes it.
By their numbers in this assay, from the lowest: compound 1; then compounds 4, 3 and 2 (each within the scatter of the next).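

In this assay, the group that brings in the amide hydrogen and a carbonyl, and that carries its aromatic ring on a carbamoylmethyl unit instead of directly on the aromatic nitrogen, leaves the number close to those of the two aryl compounds, with a 1.5-fold lower number from compound 3 to compound 4 (0.17 log units; within the scatter) and a 1.5-fold lower number from compound 2 to compound 4 (0.18 log units; within the scatter). At this position, then, the three ring-bearing groups cannot be told apart, whether the ring is bound directly to the nitrogen or not. Compound 1 remains apart from this new group too, with a 2.4-fold higher number from compound 1 to compound 4 (0.38 log units; beyond the scatter), so the decyl compound keeps the lowest number of the four.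

Open, from the compounds shown here alone, is whether a shorter alkyl chain, a longer chain, an amine or a carboxylic acid on this nitrogen would join compound 1 or the other three. Nothing shown accounts for the gap between compound 1 and the ring-bearing compounds.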